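Methoxy for Methyl on a Weak Acid

The source may hold more compounds than are shown below. What is called first, only, known or untested is meant among the compounds shown, and "the series" means these compounds.

Of the compounds shown here, two have been measured in an assay on CHO cells for displacement of a labelled ligand from prostaglandin E2 receptor EP1 subtype (Mus musculus), read by scintillation counting; on this read-out higher numbers stand for weaker inhibition and lower numbers for stronger inhibition. Compound 1, `O=C(O)/C=C/c1ccc(Cn2cccn2)cc1OCCc1ccc2ccccc2c1`, gives 2900 nM in this assay. Compound 2, `Cc1ccc(/C=C/C(=O)O)c(OCCC2(C)CCc3c(C)c(O)c(C)c(C)c3O2)c1`, gives only a limit of this assay, > 10000 nM, and no number, so it sits at the limit of > 10000 nM in this assay, at which 1 of the 2 values shown sits. On the numbers shown, compound 2 therefore stands at the weak end, beyond where compound 1 was measured.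

Compound 3, `COc1ccc(/C=C/C(=O)O)c(OCCC2(C)CCc3c(C)c(O)c(C)c(C)c3O2)c1`, has not yet been measured. It differs from compound 2 by methoxy in place of methyl on an aromatic carbon. Within the data shown here, no step between measured compounds is available here, so nothing in these data says how large such a change turns out in this assay. The step that this estimate means is a number no higher from compound 2 to compound 3 (the limit leaves the size open), expected to be small and possibly within the scatter. Compound 3 is expected to give about 10000 nM, between 3000 nM and 30000 nM, with a real chance that only a limit is reported again.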

Compound 3, inhibition constant: > 10000 nM
Compound 3: no number, only a limit (the forecaster's own chance of this, stated with the estimate: 60%); the middle value sits exactly at the limit.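

Compound 2 and compound 3 each give only a limit and no number, so no step between them can be read: the limit of > 10000 nM in this assay, at which 2 of the 3 values shown sit.

The compounds shown leave open how strongly either one actually inhibits, and whether methoxy in place of methyl on an aromatic carbon makes any difference.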